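A Fluorine Removed: Cytotoxicity Expectation for Compound 3

The compounds below may be only part of what the source reports. "The series", "measured", "known", "first", "only" and "open" are said of these compounds alone.

Compound 1, `O=C(Nc1ccc(F)c(-c2nc3ncc(-c4ccccc4F)cc3[nH]2)c1)N1CCCC1`: in an ADME assay on HepG2 cells (Homo sapiens) for cytotoxicity, read by resazurin assay, with a stated time of 48 h (a higher number here means that more compound is needed for the effect, a lower number that less compound is needed), compound 1 gives > 50000 nM, which is a limit of the assay rather than a number.
Compound 2, `O=C(Nc1ccc(F)c(-c2nc3ncc(-c4ccc(F)cc4F)cc3[nH]2)c1)N1CCCC1`: in this assay compound 2 gives 32400 nM.

For the measured compounds named here, compound 2 therefore stands as the only actual number recorded in this assay; the other value is a limit. Going by the values given here, the single measured step, an at least 1.5-fold lower number from compound 1 to compound 2 (0.18 log units; that floor lies within the scatter), was fluoro in place of hydrogen on an aromatic carbon, and its size is bounded only because the limit of > 50000 nM in this assay, at which 1 of the 2 values shown sits, caps what compound 1 could show. Compound 3, `O=C(Nc1ccc(F)c(-c2nc3ncc(-c4ccc(F)cc4)cc3[nH]2)c1)N1CCCC1`, is reached by the change hydrogen in place of fluoro on an aromatic carbon, the carbon sitting ortho to a large group and meta to a fluoro group. Among the compounds with values here, the measured step added a fluoro and moved the number by an amount whose floor lies within the scatter; the present step removes a fluoro elsewhere on the same ring, and no measured pair covers that exact position. Compound 3 is expected to show no step beyond the scatter, a step of roughly a 1.2-fold higher number from compound 2 to compound 3 (0.09 log units; within the scatter) in this assay. Compound 3 is estimated at 40000 nM, between 18000 nM and 90000 nM.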

Compound 3, half-maximal effective concentration: > 50000 nM
Compound 3 ended at the assay's limit (the forecaster's own chance of this, stated with the estimate: 40%); middle value at least 1.2-fold (0.09 log units) from the limit.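

The new step adds a reading for the carbon that the change from 2,4-difluorophenyl to 4-fluorophenyl empties, which the earlier step, made at a different carbon of the same ring, did not cover: hydrogen in place of fluoro there gives an at least 1.5-fold higher number from compound 2 to compound 3 (0.18 log units; that floor lies within the scatter). Compound 2 now stands as the only one of the three with a number, and it is also the only one carrying both fluoro groups on this ring, while each single-fluoro compound, compound 1 and compound 3, ends at a limit in this assay, although neither step from compound 2 is shown to exceed the scatter. The size of the new step is known only as a floor, and the step between compound 1 and compound 3 cannot be read, because the read-out stops at a limit: the limit of > 50000 nM in this assay, at which 2 of the 3 values shown sit.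

From the compounds shown here alone, how far compound 1 and compound 3 lie past that limit remains open. Also open, going by these compounds, is whether a chloro group, a methoxy group or an amine on the emptied carbon would give a number in this assay, and no line here bears on that.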